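Dihydroxypropoxy in place of allyloxy on the shared core

The source may hold more compounds than are shown below. What is called first, only, known or untested is meant among the compounds shown, and "the series" means these compounds.

compound 1 `O=c1c(-c2ccc(O)cc2)coc2cc(OCCCBr)ccc12` — 90.8%
compound 2 `C=CCOc1ccc2c(=O)c(-c3ccc(O)cc3)coc2c1` — 89.3%

Of the compounds shown here, two have been measured in a functional assay on mitochondria (Cricetulus griseus) for inhibition of Monoamine oxidase (Homo sapiens), tested at 3 uM; a higher number here means a stronger effect of the compound at the concentration tested, a lower number a weaker effect. Compound 1 gives 90.8% and compound 2 gives 89.3%, so compound 2 sits within the scatter of compound 1; the step of a number 1.5 percentage points lower from compound 1 to compound 2 (within the scatter) carries no weight on its own. Compound 3 `O=c1c(-c2ccc(O)cc2)coc2cc(OCC(O)CO)ccc12` is the next member, differing from compound 2 in one place: 1,2-dihydroxyethyl in place of vinyl on a saturated chain carbon bound to an oxygen on an aromatic ring. Going by the values given here, the only measured step on this chain carbon is a number 1.5 percentage points lower from compound 1 to compound 2 (within the scatter), which changed nothing beyond the scatter, and no measured pair puts a dihydroxyethyl group at this position, so there is no direct precedent. Both measured compounds sit near the top of the scale in this assay, and a change at a chain end has so far left that untouched. The expectation for compound 3 is therefore a step of a number 9.3 percentage points lower from compound 2 to compound 3 (within the scatter), likely small, with a wider downward than upward range; the estimate for compound 3 is 80%, between 55% and 95%.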

Compound 3, a percentage reported as inhibition, at one concentration (the size of the read-out at that concentration, not a potency): 85%
Compound 3: the middle estimate sits 5 percentage points below what was measured, within the range that was stated.
By their numbers in this assay, from the lowest: compounds 3, 2 and 1 (each within the scatter of the next).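

In this assay, the step to the 1,2-dihydroxyethyl group is a number 4.3 percentage points lower from compound 2 to compound 3 (within the scatter), and measured against the 2-bromoethyl group it is a number 5.8 percentage points lower from compound 1 to compound 3 (within the scatter). The earlier pair showed only that vinyl and 2-bromoethyl could be exchanged at this saturated chain carbon without a change beyond the scatter; this result extends that to a group with two hydrogen-bond donors and two hydrogen-bond acceptors, where vinyl has none. Nothing available explains why the read-out stays within the scatter across these three groups.

On these data alone, these figures come from a single concentration and show only the size of the effect at that concentration, so whether any of the three compounds would have a stronger or weaker effect at another concentration remains open. Also open, as far as these compounds go, is whether an amine, a carboxylic acid or a longer chain at this position would stay within the same scatter.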